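This account rests on a few compounds, and the source may have more. Where it says the series, first, only, none or still open, it means among the compounds named here.

Compound 1 `N=C(NCc1ccc(O)cc1)[C@@H]1CCC(=O)N1Cc1ccccc1` and compound 2 `COc1ccc(CNC(=N)[C@@H]2CCC(=O)N2Cc2ccccc2)cc1` share one core and differ by methyl in place of hydrogen on an oxygen on an aromatic ring. In a functional assay on SH-SY5Y cells (Homo sapiens) for cytotoxicity, read by MTT assay, with stated times of 8 h, 30 min and 12 h, tested at 5 uM (a higher number here means a stronger effect of the compound at the concentration tested, a lower number a weaker effect), compound 1 gives 37.6%, while compound 2 gives 19.5%, so this change made the step of a number 18.1 percentage points lower from compound 1 to compound 2 (beyond the scatter). Compound 3 `N=C(NCc1ccc(O)cc1)[C@@H]1CCC(=O)N1Cc1ccc(F)cc1` carries a different core, which differs from the core of compound 1 by fluoro in place of hydrogen on an aromatic carbon; in this assay compound 3 gives 48.6%, the step of a number 11 percentage points higher from compound 1 to compound 3 (beyond the scatter), and it stands highest of the three. Compound 4 `COc1ccc(CNC(=N)[C@@H]2CCC(=O)N2Cc2ccc(F)cc2)cc1` has not yet been measured; it differs from compound 3 by methyl in place of hydrogen on an oxygen on an aromatic ring, the same change at the same place that turned compound 1 into compound 2. The expectation for compound 4 rests on that single earlier instance, the step of a number 18.1 percentage points lower from compound 1 to compound 2 (beyond the scatter). The step from compound 3 to compound 4 is therefore expected to be a number 18.1 percentage points lower from compound 3 to compound 4 (beyond the scatter). Compound 4 is expected to give 30.5%, most likely between 18% and 43%.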

Compound 4, a percentage reported as activity, at one concentration (the size of the read-out at that concentration, not a potency): 38.1%
Beside the measured number, compound 4's estimate is 7.6 percentage points below it, and the stated range covers the measured number.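

In this assay the change from hydroxy to methoxy, made on the core that carries the fluoro group, gives a number 10.5 percentage points lower from compound 3 to compound 4 (beyond the scatter) and so repeats the earlier step in direction and, within the scatter, in size: the same change on two cores in this assay, a number 18.1 percentage points lower (beyond the scatter) from compound 1 to compound 2 and a number 10.5 percentage points lower (beyond the scatter) from compound 3 to compound 4, 7.6 percentage points apart, within the scatter of two such steps. Adding the fluoro group to the methoxy compound gives a number 18.6 percentage points higher from compound 2 to compound 4 (beyond the scatter) and likewise repeats the earlier fluoro step: the same change on two cores in this assay, a number 11 percentage points higher (beyond the scatter) from compound 1 to compound 3 and a number 18.6 percentage points higher (beyond the scatter) from compound 2 to compound 4, 7.6 percentage points apart, within the scatter of two such steps. Among these compounds, this shows that each change carried over between these two cores, but with only one such pair it does not show that either change would behave the same way on other cores. The compounds shown leave open what an ethoxy group or an amine would do in place of the hydroxy. They also leave open whether a chloro group would act like the fluoro.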